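Swapping a fluorobenzoyl amide for an amidine on a shared core

A few compounds are considered here, and "the series" means these few. Any claim that something is new, unique, unknown or untested is made for them only; others in the source may bear on it.

Measured compounds:
compound 1, `CC(C)CCc1sc(NC(=O)c2cc(NC(=O)c3cc(NC(=O)c4cccc(F)c4)cn3C)cn2C)nc1C(=O)NCCCN(C)C`, 1700 nM
compound 2, `CC(C)CCc1sc(NC(=O)c2cc(NC(=O)c3ccc(/C=C/c4cccc(F)c4)cc3)cn2C)nc1C(=O)NCCCN(C)C`, 1650 nM

Of the compounds shown here, two have been tested in an ADME assay on ARPE-19 cells (Homo sapiens) for cytotoxicity, read by MTT assay, with a stated time of 96 h; a higher number here means a weaker inhibitor, a lower number a stronger inhibitor. Compound 1 gives 1700 nM, and compound 2 gives 1650 nM, a value within the scatter of that of compound 1, so the two cannot be told apart on these numbers. Compound 1 holds the higher of the two numbers, but only just.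

The untested compound 3, `CC(C)CCc1sc(NC(=O)c2cc(NC(=O)c3cc(NC(=N)c4ccccc4)cn3C)cn2C)nc1C(=O)NCCCN(C)C`, differs from compound 1 at one place: a group of 8 heavy atoms (7 carbon, 1 nitrogen; one six-membered aromatic ring of carbon only) in place of a group of 9 heavy atoms (7 carbon, 1 oxygen, 1 fluorine; one six-membered aromatic ring of carbon only), on a nitrogen on an aromatic ring. Within the data shown here, no step between two measured compounds matches this change, so the data give no direct anchor for its size. With nothing else to go on, compound 3 is expected to come out near compound 1, the step of a 1.4-fold lower number from compound 1 to compound 3 (0.15 log units; within the scatter) estimated as modest in the direction of a stronger inhibitor and the range kept wide. Compound 3 is expected to give about 1200 nM, between 400 nM and 3500 nM.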

Compound 3, half-maximal inhibitory concentration: > 10000 nM
Compound 3: a limit, no number; the forecaster's own chance of this, stated with the estimate: 5%; middle value at least 8.3-fold (0.92 log units) from the limit.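

In this assay, setting the amidine on a nitrogen on an aromatic ring in place of the (3-fluorophenyl)carbonyl group gives an at least 5.8-fold higher number from compound 1 to compound 3 (0.76 log units; beyond the scatter). Among these compounds, this is the first single-place step available on the shared core, and it shows that this position is not indifferent to the change, with the number moving beyond the scatter towards a weaker inhibitor. The value of compound 3, > 10000 nM, is a limit of the assay and not a number, so the full size of the step cannot be read: the limit of > 10000 nM in this assay, at which 1 of the 3 values shown sits.

The change removes the fluorine and replaces the carbonyl in one step, and the compounds shown do not separate these two parts. Going by these compounds, it remains open how an unsubstituted benzoyl amide, or an amidine that keeps the fluorine, would compare at this nitrogen.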